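Working notes: methoxy to hydroxy in the series

The source may hold more compounds than are shown below. What is called first, only, known or untested is meant among the compounds shown, and "the series" means these compounds.

Values in a functional assay, with a stated time of 10 min; a lower number here means a stronger inhibitor, a higher number a weaker inhibitor:
- Compound 1 `O=c1cc(/C=C/c2ccccc2)occ1O`: 2250 nM
- Compound 2 `COc1ccccc1/C=C/c1cc(=O)c(O)co1`: 3470 nM
- Compound 3 `O=c1cc(/C=C/c2ccccc2O)occ1O`: not yet measured

Within the data shown here, compound 2 lies within the scatter of the only other measured compound, with a 1.5-fold higher number from compound 1 to compound 2 (0.19 log units; within the scatter) as the sole measured step. The change to compound 3, methoxy to hydroxy, is hydrogen in place of methyl on an oxygen on an aromatic ring and puts hydrogen in place of methyl on an oxygen on an aromatic ring. The measured step, methoxy in place of hydrogen on an aromatic carbon, is the only one that bears on this change, and it stayed within the scatter. Among the measured compounds shown here, no measured pair shows the methoxy to hydroxy change itself, so its size is not known directly. No step beyond the scatter is expected in this assay in either direction, and the range is kept wide. The expected size of the change is a 1.4-fold lower number from compound 2 to compound 3 (0.14 log units; within the scatter) as an estimate only. Compound 3 is estimated at 2500 nM with 800 nM to 7500 nM as the expected range.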

Compound 3, half-maximal inhibitory concentration: 1180 nM
Compound 3: the middle estimate sits 2.1-fold (0.33 log units) above what was measured, and the stated range covers the measured number.
By their numbers in this assay, from the lowest: compounds 3, 1 and 2 (each within the scatter of the next, the first and the last beyond it).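

In this assay, among these compounds, replacing methoxy with hydroxy gives a 2.9-fold lower number from compound 2 to compound 3 (0.47 log units; beyond the scatter), the only step so far that lies beyond the scatter, so the group on this oxygen does affect the read-out. Adding the hydroxy gives a 1.9-fold lower number from compound 1 to compound 3 (0.28 log units; within the scatter), which means that compound 3 cannot be separated from compound 1, and the gain over compound 2 does not amount to a gain over the unsubstituted ring. No data shown here account for the difference between methoxy and hydroxy.

The compounds shown leave open whether an amine in place of the hydroxy would keep the number of compound 3. They also leave open how a longer chain on the oxygen, such as ethoxy, would compare with methoxy.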